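Thiophene in Place of Phenyl: Expected Cytotoxicity of Compound 3

The source may report more compounds than this note shows. Statements on the series, on what has been measured and on what is new or still open speak of the compounds shown alone.

Measured so far:
compound 1 `NC(=O)CCSC(=S)NCc1cccnc1` — 4630 nM
compound 2 `S=C(NCc1cccnc1)SCCc1nnc(-c2ccccc2)o1` — 2770 nM

Both compounds were tested in a functional assay on MDA-MB-468 cells (Homo sapiens) for cytotoxicity, read by resazurin assay, with a stated time of 72 h; on this read-out lower numbers stand for stronger inhibition and higher numbers for weaker inhibition. Compound 1 gives 4630 nM, and compound 2 gives 2770 nM. Compound 2 has the lower of the two numbers, but compound 1 sits close enough that the gap lies within the usual scatter of repeated measurements, so the two cannot be ranked against each other.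

Compound 3 `S=C(NCc1cccnc1)SCCc1nnc(-c2ccsc2)o1` has not been measured yet. It differs from compound 2 in one place: thiophen-3-yl in place of phenyl on an aromatic carbon. The rest of the shared core, including the pyridin-3-ylmethyl group, is unchanged.

Within the data shown here, no measured pair shows what this kind of change does in this assay, so there is no step to lean on. The expectation is that the step from compound 2 to compound 3 stays within the scatter, with no clear direction, because compound 2 gives 2770 nM and nothing in the data points away from it. The expected step is a 1.1-fold lower number from compound 2 to compound 3 (0.03 log units; within the scatter). Compound 3 is estimated at 2600 nM, with a range from 1000 nM to 6500 nM.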

Compound 3, half-maximal inhibitory concentration: 3260 nM
The estimate for compound 3 lay 1.3-fold (0.10 log units) below the measured number; low and high end bracket the measured number.
By their numbers in this assay, from the lowest: compounds 2, 3 and 1 (each within the scatter of the next).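

In this assay, putting thiophen-3-yl in place of phenyl on the aromatic carbon next to the ring nitrogen and next to the ring oxygen gives a 1.2-fold higher number from compound 2 to compound 3 (0.07 log units; within the scatter), so compound 2 and compound 3 cannot be told apart on this read-out. Among these compounds, this is the first measured step at this position, and it shows that a five-membered aromatic ring with a sulfur atom can stand in for a six-membered ring of carbon only, with one heavy atom fewer and one hydrogen-bond acceptor more, and leave the number within the scatter. Nothing measured on these compounds bears on why this swap leaves the two numbers so close.

Both groups tested here are uncharged aromatic rings, so this single step says little about how far the position tolerates other kinds of group. Going by these compounds, it remains open whether a phenyl ring carrying an amine or a carboxylic acid, a saturated ring such as cyclohexyl, or a small methyl group at the same place would move the number beyond the scatter.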